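This account rests on a few compounds, and the source may have more. Where it says the series, first, only, none or still open, it means among the compounds named here.

Compound 2 `C=CCc1cc(OC)c(OC(C)C(OCCCCCCCCCC)c2ccc(O)c(OC)c2)c(OC)c1` stands with the highest of the two numbers in an assay on HEK293 cells for agonist activity at transient receptor potential cation channel subfamily M member 8 (Homo sapiens), read by fluorescence and calcium flux, with a stated time of 5 min (on this read-out higher numbers stand for an effect only at larger amounts of compound and lower numbers for an effect already at smaller amounts), where compound 2 gives 66 nM; compound 1 `C=CCc1cc(OC)c(OC(C)C(O[C@@H]2C[C@H](C)CC[C@H]2C(C)C)c2ccc(O)c(OC)c2)c(OC)c1` gives 28 nM. Going by the values given here, the one step bearing on it, a 2.4-fold higher number from compound 1 to compound 2 (0.37 log units; beyond the scatter), was modest. Compound 3 `C=CCc1cc(OC)c(OC(C)C(OCC)c2ccc(O)c(OC)c2)c(OC)c1` differs from compound 2 by hydrogen in place of octyl on a saturated chain carbon, two bonds along the chain from an oxygen on a saturated carbon, a larger trimming than that step covered. A further rise is expected: compound 3 is estimated at 220 nM, range 60 nM to 800 nM, meaning an expected step of a 3.3-fold higher number from compound 2 to compound 3 (0.52 log units; beyond the scatter) in this assay.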

Compound 3, half-maximal effective concentration: 332 nM
Estimate against measurement, compound 3: 1.5-fold (0.18 log units) below; measured number inside the range.
By their numbers in this assay, from the lowest: compound 1; then compound 2; then compound 3.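

In this assay, the chain on this oxygen matters in its own right: cutting decyl back to ethyl gives a 5.0-fold higher number from compound 2 to compound 3 (0.70 log units; beyond the scatter), so the response is not limited to the exchange of the 2-isopropyl-5-methylcyclohexyl group for a chain. Taken from the 2-isopropyl-5-methylcyclohexyl group to ethyl, the change gives a 12-fold higher number from compound 1 to compound 3 (1.07 log units; beyond the scatter), the only large step in the series. Nothing available explains these rises.

Still open, from the compounds shown here alone, are intermediate chains such as butyl or hexyl, and how a chain carrying an amine or a carboxylic acid would read here.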